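A few compounds are considered here, and "the series" means these few. Any claim that something is new, unique, unknown or untested is made for them only; others in the source may bear on it.

Of the compounds shown here, three that share one core have been read in a functional assay on SW-620 cells (Homo sapiens) for antiproliferative activity, read by MTT assay, with a stated time of 72 h; on this read-out lower numbers stand for stronger inhibition and higher numbers for weaker inhibition. Compound 1 `O=C1O/C(=C\Cn2cnc3cc[nH]c3c2=O)C(OCc2ccccc2)=C1OCc1ccccc1` gives > 100000 nM, which is a limit of the assay and not a number. Compound 2 `O=C1O/C(=C\Cn2cnc3ccnc(Cl)c32)C(OCc2ccccc2)=C1OCc1ccccc1` gives > 100000 nM, again a limit. Compound 3 `O=C1O/C(=C\Cn2cnc3ncc(Br)c-3c2)C(OCc2ccccc2)=C1OCc1ccccc1` gives > 100000 nM, also a limit. The whole set so far comes down to the limit of > 100000 nM in this assay, at which 3 of the 3 values shown sit.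

Compound 4 `O=C1O/C(=C\Cn2cnc3c(Cl)c(F)nc(F)c32)C(OCc2ccccc2)=C1OCc1ccccc1` alters the group on a saturated chain carbon bound to a double-bonded chain carbon: a group of 12 heavy atoms (6 carbon, 3 nitrogen, 2 fluorine, 1 chlorine; one five-membered aromatic ring with 2 hetero atoms, one six-membered aromatic ring with 1 hetero atom) in place of a group of 10 heavy atoms (6 carbon, 3 nitrogen, 1 bromine; one five-membered aromatic ring with 1 hetero atom, one six-membered aromatic ring with 2 hetero atoms), on a saturated chain carbon bound to a double-bonded chain carbon. The measured steps that bear on this are a step that the two limits leave unreadable from compound 1 to compound 3 and a step that the two limits leave unreadable from compound 2 to compound 3, so neither offers a size to carry over. Going by the values given here, the new group has the same ring counts as the one in compound 2, and that group did not lift compound 2 off its limit of > 100000 nM. Only a small move towards stronger inhibition is therefore expected, and compound 4 may well stay at the limit. The expected change is an at least 1.6-fold lower number from compound 3 to compound 4 (0.22 log units; that floor lies within the scatter). For compound 4 the estimated value is 60000 nM, with an expected range from 10000 nM to 100000 nM.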

Compound 4, half-maximal inhibitory concentration: 50000 nM
Estimate against measurement, compound 4: 1.2-fold (0.08 log units) above; the range from low to high includes it.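

In this assay, going by these compounds alone, compound 4 gives 50000 nM, the first number in the set that is not a limit, so a change of the group on a saturated chain carbon bound to a double-bonded chain carbon can move this read-out. Within the data shown here, measured against the earlier compounds, the change reads as an at least 2.0-fold lower number from compound 3 to compound 4 (0.30 log units; that floor lies within the scatter), as an at least 2.0-fold lower number from compound 2 to compound 4 (0.30 log units; that floor lies within the scatter) and as an at least 2.0-fold lower number from compound 1 to compound 4 (0.30 log units; that floor lies within the scatter). Each of these is only a floor, the steps among compound 1, compound 2 and compound 3 cannot be read, and most of the set still rests on a value that is a limit and not a number: the limit of > 100000 nM in this assay, at which 3 of the 4 values shown sit.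

Compound 4 carries its chlorine and two fluorines together, so the compounds shown leave open which of these atoms matters. They also leave open what an amine, a carboxylic acid or a longer chain would do in this place.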